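This account rests on a few compounds, and the source may have more. Where it says the series, first, only, none or still open, it means among the compounds named here.

Measured so far in a functional assay on SK-MEL-28 cells (Homo sapiens) for inhibition, read by sulforhodamine B assay, with a stated time of 48 h, tested at 10 uM; a lower number here means less inhibition, a higher number more inhibition at the concentration tested (going by the name of the read-out):
compound 1 `c1ccc(-c2cn3ccnc3c(-c3ccc4ncn(C5CCCCC5)c4c3)n2)cc1`: 18%
compound 2 `COc1ccc(-c2cn3ccnc3c(-c3ccc4ncn(C5CCCCC5)c4c3)n2)cc1`: 47.7%
compound 3 `Clc1ccc(-c2cn3ccnc3c(-c3ccc4ncn(C5CCCCC5)c4c3)n2)cc1`: 12.1%

In this assay compound 3 gives the lowest of the three numbers. The nearest number is that of compound 1 and the furthest that of compound 2, the steps being a number 5.9 percentage points lower from compound 1 to compound 3 (within the scatter) and a number 35.6 percentage points lower from compound 2 to compound 3 (beyond the scatter). Compound 4 `Brc1ccc(-c2cn3ccnc3c(-c3ccc4ncn(C5CCCCC5)c4c3)n2)cc1` differs from compound 3 by bromo in place of chloro on an aromatic carbon. Going by the values given here, no measured step exchanges one halogen for another. Among the compounds with values here, the step that bears on the change is a number 5.9 percentage points lower from compound 1 to compound 3 (within the scatter), small and within the scatter, whereas the only large step, a number 29.7 percentage points higher from compound 1 to compound 2 (beyond the scatter), concerns methoxy and not a halogen. For compound 4 the expected step is therefore a number 1.9 percentage points higher from compound 3 to compound 4 (within the scatter), within the scatter. The estimate for compound 4 is 14%, with a range from 2% to 30%.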

Compound 4, a percentage reported as inhibition, at one concentration (the size of the read-out at that concentration, not a potency): 28.3%
Estimate against measurement, compound 4: 14.3 percentage points below; measured number inside the range.
By their numbers in this assay, from the lowest: compounds 3 and 1 (each within the scatter of the next); then compound 4; then compound 2.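

In this assay the two halogens are not interchangeable at this position (the step is a number 16.2 percentage points higher from compound 3 to compound 4 (beyond the scatter)), although chloro in place of hydrogen gave no step beyond the scatter. Bromo also separates from hydrogen (a number 10.3 percentage points higher from compound 1 to compound 4 (beyond the scatter)) but stays short of methoxy (a number 19.4 percentage points lower from compound 2 to compound 4 (beyond the scatter)). Nothing measured on these compounds accounts for the difference between chloro and bromo.

On these data alone, whether fluoro or iodo would continue the halogen trend remains open. So does whether an amine or a carboxylic acid on this carbon would reach or pass methoxy.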